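Tetrazolylbenzyl Replaces a Carboxy Chain on the Shared Core

The source may report more compounds than this note shows. Statements on the series, on what has been measured and on what is new or still open speak of the compounds shown alone.

Measured compounds:
- compound 1, `CC1=C(C(=O)OCc2ccccc2)C(c2ccc(-c3ccccc3C)cc2)NC(=O)N1CCCCCc1nnn[nH]1`, 72000 nM
- compound 2, `CC1=C(C(=O)OCc2ccccc2)C(c2ccc(-c3ccccc3)cc2)NC(=S)N1CCCCCC(=O)O`, "not determined" (no result reported)

In a toxicity assay on MCF7 cells (Homo sapiens) for inhibition, with a stated time of 48 h (on this read-out higher numbers stand for weaker inhibition of growth and lower numbers for stronger inhibition of growth), compound 1 gives 72000 nM, a weak effect on growth. Compound 2 carries a thiocarbonyl in place of the carbonyl of compound 1 and ends its chain in a carboxylic acid, but in this assay compound 2 has no number at all, so it stands nowhere on the scale and offers no anchor of its own.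

Compound 3, `CC1=C(C(=O)OCc2ccccc2)C(c2ccc(-c3ccccc3)cc2)NC(=S)N1Cc1ccc(-c2nnn[nH]2)cc1`, is the next compound to be tested. Against compound 2 the change is 4-(1H-tetrazol-5-yl)phenyl in place of 4-carboxybutyl on a saturated chain carbon bound to an amide-type nitrogen in a ring. Cut one bond further out, the same change reads 5-carboxypentyl to 4-(1H-tetrazol-5-yl)benzyl.

For the measured compounds named here, no measured pair shows a step of this kind, so the size of the step in this assay cannot be read from data; with compound 2 unmeasured, no direction can be given either. The only number available is that of compound 1, which is weak, and nothing shown argues for a compound far from it.

Compound 3 is expected to give 50000 nM in this assay, with a range from 12000 nM to 200000 nM.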

Compound 3, concentration for 50% growth inhibition: 140000 nM
For compound 3 the middle estimate is 2.8-fold (0.45 log units) below the measured one, within the range that was stated.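

No step can be read from compound 3: compound 2 has no single number in this assay, and compound 1 differs from compound 3 in more than one place. Nothing shown offers an explanation for the result of compound 3. As far as these compounds go, what the change from 4-carboxybutyl to 4-(1H-tetrazol-5-yl)phenyl alone does to growth inhibition stays open.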